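Dichlorophenyl substitution on the imidazopyrimidine series cytotoxicity

A few compounds are considered here, and "the series" means these few. Any claim that something is new, unique, unknown or untested is made for them only; others in the source may bear on it.

Compound 1 `C=CC(=O)Nc1cc(Nc2ncc3ncn(-c4ccccc4)c3n2)c(OC)cc1N(C)CCN(C)C` is the reference point of this small set. In an ADME assay on HT-29 cells (Homo sapiens) for cytotoxicity, read by MTT assay, with a stated time of 72 h (on this read-out lower numbers stand for stronger inhibition and higher numbers for weaker inhibition), compound 1 gives 8080 nM, the lowest of the three numbers measured. Compound 2 `C=CC(=O)Nc1cc(Nc2ncc3ncn(-c4ccc(C)cc4)c3n2)c(OC)cc1N(C)CCN(C)C` carries a methyl on the phenyl and gives 9230 nM, a step of a 1.1-fold higher number from compound 1 to compound 2 (0.06 log units; within the scatter). Compound 3 `C=CC(=O)Nc1cc(Nc2ncc3ncn(-c4ccc(C(C)C)cc4)c3n2)c(OC)cc1N(C)CCN(C)C` carries an isopropyl in the same place and gives 15300 nM, a step of a 1.9-fold higher number from compound 1 to compound 3 (0.28 log units; within the scatter); the step of a 1.7-fold higher number from compound 2 to compound 3 (0.22 log units; within the scatter) also stays within the scatter. Compound 4 `C=CC(=O)Nc1cc(Nc2ncc3ncn(-c4ccc(Cl)cc4Cl)c3n2)c(OC)cc1N(C)CCN(C)C` is not yet measured. It differs from compound 1 in one place: 2,4-dichlorophenyl in place of phenyl on an aromatic nitrogen. The two measured steps that bear on this change are both substitutions on that phenyl ring, and both gave numbers that rose only within the scatter, with compound 3 showing the larger rise. On this basis no step beyond the scatter is expected in this assay for compound 4, with at most a slight lean toward a higher number. Compound 4 is therefore estimated at 10500 nM, with a range from 4500 nM to 24000 nM. The expected step is a 1.3-fold higher number from compound 1 to compound 4 (0.11 log units; within the scatter).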

Compound 4, half-maximal inhibitory concentration: 20600 nM
For compound 4 the middle estimate is 2.0-fold (0.29 log units) below the measured one; measured number inside the range.
By their numbers in this assay, from the lowest: compounds 1, 2, 3 and 4 (each within the scatter of the next, the first and the last beyond it).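

In this assay, going by these compounds alone, the 2,4-dichlorophenyl group on the ring nitrogen produces the first step at this position that lies beyond the scatter (a 2.5-fold higher number from compound 1 to compound 4 (0.41 log units; beyond the scatter)), and the comparison with the 4-methylphenyl group also lies beyond it (a 2.2-fold higher number from compound 2 to compound 4 (0.35 log units; beyond the scatter)). Against the 4-isopropylphenyl group, the change remains within the scatter (a 1.3-fold higher number from compound 3 to compound 4 (0.13 log units; within the scatter)), so the set separates compound 4 from compound 1 and compound 2 but not from compound 3. No measured evidence accounts for this modest step.

The compounds shown leave open how a 4-chlorophenyl group, with its single chlorine, would compare with the 2,4-dichlorophenyl group. They also leave open whether an amine or a carboxylic acid on the phenyl ring would move the number in either direction.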